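Acetylated tert-butylphenyl analogue in the NUGC-3 cytotoxicity series

A few compounds are considered here, and "the series" means these few. Any claim that something is new, unique, unknown or untested is made for them only; others in the source may bear on it.

Measured so far:
compound 1, `CCCCc1ccc(-c2cc(-c3cn([C@H]4C[C@H](OC(C)=O)[C@@H](COC(C)=O)O4)c(=O)[nH]c3=O)on2)cc1`, 39.8%
compound 2, `CCCCCCCCc1cc(-c2cn([C@H]3C[C@H](O)[C@@H](CO)O3)c(=O)[nH]c2=O)on1`, 76.4%
compound 3, `CC(C)(C)c1ccc(-c2cc(-c3cn([C@H]4C[C@H](O)[C@@H](CO)O4)c(=O)[nH]c3=O)on2)cc1`, 88%

In a functional assay on NUGC-3 cells (Homo sapiens) for cytotoxicity, read by sulforhodamine B assay, tested at 10 uM (on this read-out lower numbers stand for less inhibition and higher numbers for more inhibition at the one concentration tested (going by the name of the read-out)), compound 1 gives 39.8%, the lowest of the three numbers; compound 2 stands higher, beyond the scatter, and compound 3 higher still, beyond the scatter. Compound 1 and compound 3 differ in more than one place, so their gap is read only as what the two values show, not as a single step.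

The unmeasured compound 4, `CC(=O)OC[C@H]1O[C@@H](n2cc(-c3cc(-c4ccc(C(C)(C)C)cc4)no3)c(=O)[nH]c2=O)C[C@@H]1OC(C)=O`, is reached from compound 1 by the change (tert-butyl in place of butyl on an aromatic carbon); cut one bond further out, this reads 4-(tert-butyl)phenyl in place of 4-butylphenyl. Among the measured compounds shown here, no measured pair isolates this change. For the measured compounds named here, the only single step within the set, a number 11.6 percentage points higher from compound 2 to compound 3 (beyond the scatter), swaps 4-(tert-butyl)phenyl for octyl on the free-diol core and is modest; it concerns the same entering group but a different leaving group and a different core, so it bears on the present step only loosely.

On that basis the step from compound 1 to compound 4 is expected to be small, estimated at a number 6.2 percentage points higher from compound 1 to compound 4 (within the scatter), with no confident direction beyond the scatter. Compound 4 is therefore estimated at 46% in this assay, within 26% to 70%.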

Compound 4, a percentage reported as inhibition, at one concentration (the size of the read-out at that concentration, not a potency): 32.8%
Compound 4: middle estimate off by 13.2 percentage points, on the high side; measured number inside the range.
By their numbers in this assay, from the lowest: compounds 4 and 1 (each within the scatter of the next); then compound 2; then compound 3.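

In this assay, tert-butyl in place of butyl on an aromatic carbon, para to a large group, gives a number 7 percentage points lower from compound 1 to compound 4 (within the scatter), and this is the first pair shown that isolates this position with nothing else altered. Butyl and tert-butyl hold the same atoms joined differently, and on the core shared by compound 1 and compound 4 that rearrangement leaves the read-out within the scatter at the one concentration tested, so this result gives no sign that the shape of the four-carbon group matters on this core. Nothing available bears on why the two compounds read as they do.

The compounds shown leave open whether the same change would also stay within the scatter on the free-diol core of compound 3, which gives 88% in this assay and is the only compound of that core with a substituted phenyl group. They also leave open how this position would respond to a group of a different kind, such as an amine or a carboxylic acid in place of the tert-butyl.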